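Chain extension on the amine of compound 3

The source may hold more compounds than are shown below. What is called first, only, known or untested is meant among the compounds shown, and "the series" means these compounds.

Among the compounds with values here, three measured compounds make up the series so far. Compound 1 `Cc1ccc(CNc2nc(NCc3ccc(C)cc3)c3cccnc3n2)cc1` and compound 2 `COc1ccc(CNc2nc(NCc3ccc(OC)cc3)c3cccnc3n2)cc1` share one core; compound 3 `CCCCNc1nc(SCC)nc2ncccc12` has a different core with a butyl on its amine. In a functional assay on HT-29 cells (Homo sapiens) for cytotoxicity, read by neutral red uptake, with a stated time of 72 h (on this read-out lower numbers stand for stronger inhibition and higher numbers for weaker inhibition), compound 1 gives 7500 nM and compound 2 gives 8900 nM. In this assay compound 3 gives 25300 nM, the highest of the three numbers, with the nearest value from compound 2 and the furthest from compound 1, both gaps beyond the scatter. Within the data shown here, no pair of measured compounds differs in one place, so no step is available.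

Compound 4 `CCCCCCCNc1nc(SCC)nc2ncccc12` is the next member, not yet measured. It differs from compound 3 by propyl in place of hydrogen on a saturated chain carbon, four bonds along the chain from a nitrogen on an aromatic ring. Nothing in the measured set shows what a chain extension of this kind does in this assay, so the direction is uncertain. The step from compound 3 to compound 4 is expected to be small, a 1.4-fold lower number from compound 3 to compound 4 (0.15 log units; within the scatter), not clearly beyond the scatter in either direction. Compound 4 is estimated at 18000 nM in this assay, with a range from 6000 nM to 55000 nM.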

Compound 4, half-maximal inhibitory concentration: 19900 nM
Compound 4: middle estimate off by 1.1-fold (0.04 log units), on the low side, and the stated range covers the measured number.
By their numbers in this assay, from the lowest: compounds 1 and 2 (each within the scatter of the next); then compounds 4 and 3 (each within the scatter of the next).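

Chain extension read in one step: in this assay, propyl in place of hydrogen on a saturated chain carbon, four bonds along the chain from a nitrogen on an aromatic ring, gives a 1.3-fold lower number from compound 3 to compound 4 (0.10 log units; within the scatter). Within the data shown here, this is the first step that can be read at all, and it shows that adding propyl, with its 3 heavy atoms and no ring, at this position does not separate the pair beyond the scatter, so this change on this chain brings neither a clear gain nor a clear loss on this read-out. No evidence on hand bears on this result.

A single step on a single chain leaves open whether a longer chain would stay equally flat, or whether an amine, a hydroxyl or a carboxylic acid in place of propyl on that saturated chain carbon would move the number beyond the scatter. Also open, on these data alone, is whether a phenyl ring at this position would do so in this assay, and whether any change here can bring the core of compound 3 into a clearly different range.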